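This account rests on a few compounds, and the source may have more. Where it says the series, first, only, none or still open, it means among the compounds named here.

Compound 1 `CN1CCN(CCCS(=O)(=O)c2ccc3nc(NC(=O)NC(=O)c4cc(-n5cccn5)ccc4Cl)sc3c2)CC1` and compound 2 `CN1CCN(CCCS(=O)(=O)c2ccc3nc(NC(=O)NC(=O)c4cc(C5CC5)ccc4Cl)sc3c2)CC1` share one core. In an assay on HEK293 cells for displacement of a labelled ligand from growth hormone secretagogue receptor type 1 (Homo sapiens), with a stated time of 60 min (a higher number here means a weaker inhibitor, a lower number a stronger inhibitor), compound 1 gives 0.67 nM and compound 2 gives 0.33 nM; the change is a 2.0-fold lower number from compound 1 to compound 2 (0.31 log units; beyond the scatter). Compound 2 thus stands at the lower of the two numbers. Compound 3 `CN1CCN(CCCS(=O)(=O)c2ccc3nc(NC(=O)NC(=O)c4cc5c(ccn5C)cc4Cl)sc3c2)CC1` differs from compound 2 by 5-chloro-1-methyl-1H-indol-6-yl in place of 2-chloro-5-cyclopropylphenyl on a carbonyl carbon. For the measured compounds named here, no measured step covers an exchange of the whole group on the carbonyl carbon; the one step, cyclopropyl in place of 1H-pyrazol-1-yl, was modest and only loosely related. A step of similar or smaller size is expected, in either direction, so compound 3 is estimated at 0.6 nM (range 0.2 nM to 2 nM) in this assay. The expected step of a 1.8-fold higher number from compound 2 to compound 3 (0.26 log units; within the scatter) is small.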

Compound 3, half-maximal inhibitory concentration: 0.57 nM
Estimate against measurement, compound 3: 1.1-fold (0.02 log units) above; the range from low to high includes it.
By their numbers in this assay, from the lowest: compounds 2, 3 and 1 (each within the scatter of the next, the first and the last beyond it).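

On the carbonyl carbon, 5-chloro-1-methyl-1H-indol-6-yl in place of 2-chloro-5-cyclopropylphenyl gives a 1.7-fold higher number from compound 2 to compound 3 (0.24 log units; within the scatter) in this assay and, in place of 2-chloro-5-(1H-pyrazol-1-yl)phenyl, gives a 1.2-fold lower number from compound 1 to compound 3 (0.07 log units; within the scatter) in the same assay. Both steps lie within the scatter, so for these three compounds the position accepts a whole-group exchange that brings in a five-membered aromatic ring with 1 hetero atom. Nothing available explains this result.

As far as these compounds go, what the methyl group on the indole nitrogen contributes remains open. So does the outcome of exchanging the chlorine for a methoxy group or a nitrile.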